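Swapping the ring amine of compound 2 for an open pyridylmethyl amine

This account rests on a few compounds, and the source may have more. Where it says the series, first, only, none or still open, it means among the compounds named here.

Measured compounds:
compound 1 `Nc1ccccc1NC(=O)c1ccc(CSC(=S)N2CCN(c3ccc(Cl)cc3)CC2)cc1` gives 15%
compound 2 `CC1CCCCN1C(=S)SCc1ccc(C(=O)Nc2ccccc2N)cc1` gives 64.4%
compound 3 `Nc1ccccc1NC(=O)c1ccc(CSC(=S)N2CCN(Cc3ccncc3)CC2)cc1` gives 18.4%

In a functional assay on MGC-803 cells (Homo sapiens) for antiproliferative activity, read by CCK-8 assay, with a stated time of 72 h, tested at 2 uM (a lower number here means a weaker effect, a higher number a stronger effect of the compound at the concentration tested), compound 2 stands highest of the three numbers; compound 3 lies a number 3.4 percentage points higher from compound 1 to compound 3 (within the scatter), so compounds 1 and 3 sit together well below compound 2. Compound 4 `CN(Cc1cccnc1)C(=S)SCc1ccc(C(=O)Nc2ccccc2N)cc1` differs from compound 2 in one place: methyl((pyridin-3-yl)methyl)amino in place of 2-methylpiperidin-1-yl on a thiocarbonyl carbon. Within the data shown here, the only measured step, from compound 1 to compound 3, changes the group on an amine nitrogen in a ring and lands within the scatter, so it says nothing direct about trading the 2-methylpiperidin-1-yl of compound 2 for an open amine. What the values do show is that both compounds carrying an aromatic arm on the amine, compound 1 and compound 3, are far weaker than compound 2, and compound 4 also gains such an arm. The expectation for compound 4 is therefore a drop, a number 34.4 percentage points lower from compound 2 to compound 4 (beyond the scatter), with considerable uncertainty. Compound 4 is estimated at 30%, between 10% and 55%.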

Compound 4, a percentage reported as inhibition, at one concentration (the size of the read-out at that concentration, not a potency): 45.9%
Compound 4: middle estimate off by 15.9 percentage points, on the low side, within the range that was stated.
By their numbers in this assay, from the lowest: compounds 1 and 3 (each within the scatter of the next); then compound 4; then compound 2.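

In this assay, among these compounds, the change on the thiocarbonyl carbon gives a number 18.5 percentage points lower from compound 2 to compound 4 (beyond the scatter), the first reading of a replacement of the whole amine at this place. The earlier step only changed a group on an amine nitrogen in a ring, while here the 2-methylpiperidin-1-yl ring gives way to an open amine and compound 4 still keeps 45.9%, so the ring of compound 2 is not essential for a clear effect at this concentration. Nothing available explains the loss.

This swap removes the ring and brings in the pyridin-3-yl arm in a single step, so the two changes cannot be told apart. A dimethylamino group, a plain piperidin-1-yl ring or a morpholin-4-yl ring on the same carbon would leave open how much each change contributes.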